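Cyano for fluoro on the imine-bound phenyl ring

The compounds below may be only part of what the source reports. "The series", "measured", "known", "first", "only" and "open" are said of these compounds alone.

Compound 1 `CC(=O)/C(=N\c1ccccc1)NNc1ccccc1C(F)(F)F` gives 2260 nM in an assay on isolated protein for binding affinity to corticotropin-releasing factor receptor 1 (Homo sapiens); on this read-out higher numbers stand for weaker inhibition and lower numbers for stronger inhibition.
Compound 2 `CC(=O)/C(=N\c1ccccc1Cl)NNc1ccccc1C(F)(F)F` reaches only a limit of the assay, > 10000 nM, in this assay.
Compound 3 `CC(=O)/C(=N\c1cccc(F)c1)NNc1ccccc1C(F)(F)F` gives 197 nM in this assay.

Among the numbers actually measured, compound 3 stands lowest; its nearest neighbour is compound 1, an 11-fold lower number from compound 1 to compound 3 (1.06 log units; beyond the scatter). Compound 2 supplies only a limit (the limit of > 10000 nM in this assay, at which 1 of the 3 values shown sits), so its distance from compound 3 is known as an at least 50-fold lower number from compound 2 to compound 3 (1.70 log units; beyond the scatter).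

The next compound, compound 4 `CC(=O)/C(=N\c1cccc(C#N)c1)NNc1ccccc1C(F)(F)F`, differs from compound 3 by a single change: cyano in place of fluoro on an aromatic carbon. Among the compounds with values here, no measured step swaps these two particular groups. The steps that touch this ring show that a small substituent matters: hydrogen to fluoro gave an 11-fold lower number from compound 1 to compound 3 (1.06 log units; beyond the scatter), while hydrogen to chloro at another spot gave an at least 4.4-fold higher number from compound 1 to compound 2 (0.64 log units; beyond the scatter). A cyano group is larger than a fluoro and brings one more hydrogen-bond acceptor, so the result is uncertain, and a step somewhat above the scatter, most likely toward a higher number, is expected. The estimated value for compound 4 is 450 nM, with a range from 120 nM to 1800 nM, which corresponds to an expected step of a 2.3-fold higher number from compound 3 to compound 4 (0.36 log units; beyond the scatter).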

Compound 4, inhibition constant: > 10000 nM
Compound 4: only a limit was reported; the forecaster's own chance of this, stated with the estimate: 5%; middle value at least 22-fold (1.34 log units) from the limit.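

In this assay, the swap on this aromatic carbon, meta to a large group, gives an at least 50-fold higher number from compound 3 to compound 4 (1.70 log units; beyond the scatter) and so shows that the gain seen with fluoro does not carry over to every small group placed here: fluoro leaves and cyano enters, only one heavy atom more, yet the result changes sharply. Compared with hydrogen on the same carbon, cyano gives an at least 4.4-fold higher number from compound 1 to compound 4 (0.64 log units; beyond the scatter) and so does not merely lose the gain from fluoro but ends up on the weak side of the unsubstituted compound. On these data alone, compound 4 reaches only a limit of the assay, as does compound 2, so the step between those two cannot be read, and how weak compound 4 really is stays unknown: the limit of > 10000 nM in this assay, at which 2 of the 4 values shown sit.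

The compounds shown leave open whether this loss belongs to the cyano group alone or also appears with a methyl, a methoxy or an amine on the same carbon. They also leave open whether a fluoro on another carbon of this ring would keep the gain seen with compound 3.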